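Swapping a Bicyclic Amide for a Dihydroindole Amide

The source may report more compounds than this note shows. Statements on the series, on what has been measured and on what is new or still open speak of the compounds shown alone.

Compound 1 `CC(C(=O)N1C[C@H]2CCC[C@H]2C1)N1CCN(S(=O)(=O)c2ccc(C(C)(C)C)cc2)CC1` is an amide whose carbonyl carbon carries a fused pair of five-membered rings, joined through a short chain to a sulfonyl-bearing piperazine. In an ADME assay on HepG2 cells (Homo sapiens) for inhibition, with a stated time of 48 h (on this read-out lower numbers stand for an effect already at smaller amounts and higher numbers for an effect only at larger amounts of compound), compound 1 gives > 40000 nM, which is a limit of the assay and not a measured number. Compound 2 `CC(C(=O)N1CCCCC1)N1CCN(S(=O)(=O)c2ccc(C(C)(C)C)cc2)CC1` carries piperidin-1-yl on that carbonyl carbon instead. In this assay compound 2 also reaches only a limit, > 40000 nM. Compound 3 `CC(C(=O)N1CCC(C)(C)CC1)N1CCN(S(=O)(=O)c2ccc(C(C)(C)C)cc2)CC1` carries 4,4-dimethylpiperidin-1-yl there. In this assay compound 3 again stops at a limit, > 40000 nM.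

None of the steps between these three can be sized: a step that the two limits leave unreadable from compound 1 to compound 2, a step that the two limits leave unreadable from compound 1 to compound 3 and a step that the two limits leave unreadable from compound 2 to compound 3. This follows because the limit of > 40000 nM in this assay, at which 3 of the 3 values shown sit, leaves every comparison without a readable number.

Compound 4 `CC(C(=O)N1CCc2ccccc21)N1CCN(S(=O)(=O)c2ccc(C(C)(C)C)cc2)CC1` has not yet been measured. Its change from compound 1 is a group of 9 heavy atoms (8 carbon, 1 nitrogen; one five-membered non-aromatic ring with 1 hetero atom, one six-membered aromatic ring of carbon only) in place of a group of 8 heavy atoms (7 carbon, 1 nitrogen; one five-membered non-aromatic ring of carbon only, one five-membered non-aromatic ring with 1 hetero atom), on a carbonyl carbon. Among the compounds with values here, no measured step bears on this change in a readable way, so no direction beyond the scatter can be drawn from them. The step is therefore expected to be a number no higher from compound 1 to compound 4 (the limit leaves the size open). Compound 4 is expected to give about 40000 nM, within a range from 15000 nM to 100000 nM, most likely again only as a limit.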

Compound 4, half-maximal effective concentration: > 40000 nM
Compound 4: no number, only a limit; the forecaster's own chance of this, stated with the estimate: 80%; the middle value sits exactly at the limit.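

In this assay compound 4 gives > 40000 nM, again a limit and not a number. The steps to compound 4 from compound 1, compound 2 and compound 3 cannot be read, because every value stops at the same limit: the limit of > 40000 nM in this assay, at which 4 of the 4 values shown sit.

The compounds shown leave open whether changing the group on the carbonyl carbon alters this read-out at all.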